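The compounds below may be only part of what the source reports. "The series", "measured", "known", "first", "only" and "open" are said of these compounds alone.

Measured compounds in a toxicity assay on MDCK cells (Canis lupus familiaris) for cytotoxicity, read by crystal violet staining, with a stated time of 48 h; on this read-out higher numbers stand for lower toxicity in this test and lower numbers for higher toxicity in this test:
Compound 1 `CCc1ccc2[nH]c(=O)c(CN(Cc3ccc(OCOC)cc3)Cc3ccc(C(C)(C)C)cc3)cc2c1` gives > 10000 nM, a limit of the assay.
Compound 2 `CCc1ccc2[nH]c(=O)c(CN(Cc3ccc(O)cc3)Cc3ccc(C(C)(C)C)cc3)cc2c1` gives > 10000 nM, a limit of the assay.
Compound 3 `Cc1ccc2[nH]c(=O)c(CN(Cc3ccc(OCC(=O)OC(C)(C)C)cc3)Cc3ccc(C(C)(C)C)cc3)cc2c1` gives > 10000 nM, a limit of the assay.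

Every measured value sits at the limit of > 10000 nM in this assay, at which 3 of the 3 values shown sit. Compound 3 therefore stands at the limit only, with no number behind it. Compound 4 `Cc1ccc2[nH]c(=O)c(CN(Cc3ccc(SC(F)(F)F)cc3)Cc3ccc(C(C)(C)C)cc3)cc2c1` differs from compound 3 by (trifluoromethyl)sulfanyl in place of (tert-butoxycarbonyl)methoxy on an aromatic carbon. Among the measured compounds shown here, the one step between measured compounds, a step that the two limits leave unreadable from compound 1 to compound 2, runs between two limits and gives no readable size, so no measured step bears on the exchange from compound 3 to compound 4, and no direction can be drawn from the series. The step that the limit leaves unreadable from compound 3 to compound 4 is expected to be none beyond the scatter. Compound 4 is estimated at 15000 nM, with a range of 5000 nM to 50000 nM, most likely reported as a limit again.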

Compound 4, half-maximal cytotoxic concentration: > 5000 nM
Compound 4: no number, only a limit (the forecaster's own chance of this, stated with the estimate: 75%); the middle value is on the limit's open side.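

In this assay compound 3 gives > 10000 nM, a limit. Among the compounds shown here, compound 4 gives > 5000 nM, also a limit, and no step between compound 3 and compound 4 can be read. The compounds shown leave open whether any member of the series has a measurable half-maximal cytotoxic concentration.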